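This account rests on a few compounds, and the source may have more. Where it says the series, first, only, none or still open, it means among the compounds named here.

Of the compounds shown here, three with one shared core have been measured so far. Compound 1 `Cc1nc(-c2ccccc2)c(C(=O)N2CCN(c3c(C)cccc3C)CC2)o1` gives 146 nM in a functional assay on HL-60 cells (Homo sapiens) for inhibition, read by MTT assay, with a stated time of 72 h (a lower number here means a stronger inhibitor, a higher number a weaker inhibitor), the lowest of the three numbers. Compound 2 `COc1ccc(Cl)cc1N1CCN(C(=O)c2oc(C)nc2-c2ccccc2F)CC1` gives 153 nM, and compound 3 `CCc1nc(-c2ccc(F)cc2)c(C(=O)N2CCN(c3cccc(Cl)c3)CC2)o1` gives 169 nM. All three values sit within the usual scatter of one another, so the numbers alone do not separate them. Compound 4 `COc1cc(OC)cc(N2CCN(C(=O)c3oc(C)nc3-c3ccccc3)CC2)c1` is not yet measured; it differs from compound 1 in one place: 3,5-dimethoxyphenyl in place of 2,6-dimethylphenyl on an amine nitrogen in a ring. Among the compounds with values here, no pair of measured compounds differs in a single place, so no measured step guides the expectation. The change is expected to move the number little, if at all, beyond the scatter. Compound 4 is estimated at 200 nM, with a range from 90 nM to 450 nM, an expected step of a 1.4-fold higher number from compound 1 to compound 4 (0.14 log units; within the scatter).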

Compound 4, half-maximal inhibitory concentration: 19.2 nM
Compound 4: the middle estimate sits 10-fold (1.02 log units) above what was measured; the measured number lies below the stated range.
By their numbers in this assay, from the lowest: compound 4; then compounds 1, 2 and 3 (each within the scatter of the next).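

Compound 4 shows that the group on the amine nitrogen in the ring can shift the number in this assay: 3,5-dimethoxyphenyl in place of 2,6-dimethylphenyl gives a 7.6-fold lower number from compound 1 to compound 4 (0.88 log units; beyond the scatter), the first single-place step available. This one step changes the kind of group and where the groups sit on the phenyl ring together, so it cannot tell which of the two matters. Nothing measured here explains the step.

Still open, from the compounds shown here alone, is whether one methoxy group would be enough. Also open, going by these compounds, is how an amine or a carboxylic acid on that phenyl ring would compare.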